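Trimming a Methyl from a Sulfonamide Nitrogen

The source may hold more compounds than are shown below. What is called first, only, known or untested is meant among the compounds shown, and "the series" means these compounds.

Measured so far in an assay on CHO cells for displacement of a labelled ligand from prostaglandin D2 receptor 2 (Homo sapiens), read by scintillation counting; a lower number here means a stronger inhibitor, a higher number a weaker inhibitor:
- compound 1 `Cc1ccc(S(=O)(=O)CCO)cc1C#Cc1cc(Cl)ccc1OCC(=O)O` gives 19 nM
- compound 2 `Cc1ccc(S(=O)(=O)N(C)C(C)C)cc1C#Cc1cc(Cl)ccc1OCC(=O)O` gives 3.8 nM

Among the measured compounds shown here, compound 2 has the lowest number of the two, and its only neighbour is compound 1, reached by the step of a 5.0-fold lower number from compound 1 to compound 2 (0.70 log units; beyond the scatter), in which isopropyl(methyl)amino replaced 2-hydroxyethyl on the sulfonyl sulfur. Compound 3 `Cc1ccc(S(=O)(=O)NC(C)C)cc1C#Cc1cc(Cl)ccc1OCC(=O)O` has not yet been measured in this assay. It differs from compound 2 by hydrogen in place of methyl on a sulfonamide nitrogen, so that isopropyl(methyl)amino becomes isopropylamino. For the measured compounds named here, no measured step involves such a removal of a methyl from a sulfonamide nitrogen, so the one step on record, from a sulfone to a sulfonamide, gives no direct guide. With the isopropyl group kept, the change is small, and for compound 3 the expected step is a 1.3-fold higher number from compound 2 to compound 3 (0.12 log units; within the scatter), likely within the scatter. Compound 3 is therefore estimated at 5 nM, with a range from 1.5 nM to 16 nM.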

Compound 3, inhibition constant: 3.4 nM
The estimate for compound 3 lay 1.5-fold (0.17 log units) above the measured number; the range from low to high includes it.
By their numbers in this assay, from the lowest: compounds 3 and 2 (each within the scatter of the next); then compound 1.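

Taking the methyl off the sulfonamide nitrogen, a step of (a 1.1-fold lower number from compound 2 to compound 3 (0.05 log units; within the scatter)) in this assay, shows that with the isopropyl group kept, this nitrogen can carry either a hydrogen or a methyl with no difference that stands out from the scatter. The advantage over the sulfone therefore does not depend on that methyl, since the step (a 5.6-fold lower number from compound 1 to compound 3 (0.75 log units; beyond the scatter)) lies beyond the scatter, just as the step to compound 2 does. Nothing on hand explains why these numbers fall as they do.

Still open is what the isopropyl group contributes, since all the sulfonamides shown keep it, and a plain amino group, an ethyl or a tert-butyl on the same nitrogen would test this. Also open, on these data alone, is whether a hydroxyl group or a longer chain on this nitrogen would behave like the 2-hydroxyethyl of compound 1.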